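Trading a Trichlorophenyl Group for a Hydroxymethoxyphenyl Group

The source may report more compounds than this note shows. Statements on the series, on what has been measured and on what is new or still open speak of the compounds shown alone.

Within the data shown here, in a functional assay on DU-145 cells (Homo sapiens) for inhibition, read by trypan blue exclusion, with a stated time of 96 h (on this read-out lower numbers stand for stronger inhibition of growth and higher numbers for weaker inhibition of growth), compound 1 `Cc1ccc(S/C(=C/c2cc(Cl)cc(Cl)c2Cl)C(=O)c2ccc(Cl)cc2)cc1` gives 50000 nM, the only true number available so far. Compound 2 `CN(C)c1ccc(/C=C(/SCc2ccccc2Cl)C(=O)c2ccc(Cl)cc2)cc1` reads > 100000 nM, which is a limit of the assay and not a number. Compound 3 `COc1ccc(/C=C(/Sc2ccc(C)cc2)C(=O)c2ccc(Cl)cc2)cc1O` carries 3-hydroxy-4-methoxyphenyl in place of 2,3,5-trichlorophenyl on a double-bonded chain carbon bound to a double-bonded chain carbon. Among the measured compounds shown here, no measured step guides this change. Compound 1 at 50000 nM is a weak starting point, so movement toward stronger inhibition is expected. The estimated move is a large one, a 17-fold lower number from compound 1 to compound 3 (1.22 log units; beyond the scatter). For compound 3 the expected value is 3000 nM, with an estimated range from 300 nM to 30000 nM.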

Compound 3, concentration for 50% growth inhibition: 1000 nM
Estimate against measurement, compound 3: 3.0-fold (0.48 log units) above, and the stated range covers the measured number.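

In this assay, 3-hydroxy-4-methoxyphenyl in place of 2,3,5-trichlorophenyl gives a 50-fold lower number from compound 1 to compound 3 (1.70 log units; beyond the scatter) with the rest of the structure unchanged. This single change on a double-bonded chain carbon bound to a double-bonded chain carbon is thus enough to move the read-out well beyond the scatter, although both groups have 9 heavy atoms and only the entering group has hydrogen-bond donors or acceptors. Nothing shown here explains why the number falls.

Whether the hydroxy group or the methoxy group accounts for the step remains open, since the two entered together. From the compounds shown here alone, how an amine or a carboxylic acid on the ring at this place would read also remains open.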